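The source may report more compounds than this note shows. Statements on the series, on what has been measured and on what is new or still open speak of the compounds shown alone.

Compound 2 `CC(=O)N1CCN(C(=O)N2CCCC[C@H]2C(=O)Nc2cc(C(C)(C)C)on2)CC1` gives 62 ug/mL in a physicochemical assay for solubility, read by HPLC, at pH 6.8 (on this read-out higher numbers stand for higher solubility and lower numbers for lower solubility), the larger of the two numbers recorded so far, although compound 1 `CC(C)(C)c1cc(NC(=O)[C@@H]2CCCCN2C(=O)N2CCOCC2)no1` with 45 ug/mL sits within the scatter of it, as the step of a 1.4-fold higher number from compound 1 to compound 2 (0.14 log units; within the scatter) shows. Compound 3 `CCC(=O)N1CCN(C(=O)N2CCCC[C@H]2C(=O)Nc2cc(C(C)(C)C)on2)CC1` differs from compound 2 by methyl in place of hydrogen on a saturated chain carbon bound to a carbonyl carbon. For the measured compounds named here, the only measured step, from compound 1 to compound 2, exchanged a whole ring group and still stayed within the scatter, so a single added methyl is expected to produce no step beyond the scatter in this assay. Compound 3 is therefore expected to give 55 ug/mL, between 28 ug/mL and 110 ug/mL, a step of a 1.1-fold lower number from compound 2 to compound 3 (0.05 log units; within the scatter).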

Compound 3, solubility: 68 ug/mL
Estimate against measurement, compound 3: 1.2-fold (0.09 log units) below; the range from low to high includes it.
By their numbers in this assay, from the lowest: compounds 1, 2 and 3 (each within the scatter of the next).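

In this assay, the methyl that turns 4-acetylpiperazin-1-yl into 4-propanoylpiperazin-1-yl gives a 1.1-fold higher number from compound 2 to compound 3 (0.04 log units; within the scatter), so this small addition on a saturated chain carbon bound to a carbonyl carbon is not distinguishable from the scatter. Placing 4-propanoylpiperazin-1-yl where morpholin-4-yl stood gives a 1.5-fold higher number from compound 1 to compound 3 (0.18 log units; within the scatter), which also stays within the scatter. Nothing available gives a reason for these results. Still open, from the compounds shown here alone, is whether a longer chain, an amine or a carboxylic acid at this place would produce a step beyond the scatter.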